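This account rests on a few compounds, and the source may have more. Where it says the series, first, only, none or still open, it means among the compounds named here.

In an ADME assay on L929 cells (Mus musculus) for cytotoxicity, read by resazurin assay, with a stated time of 72 h (a lower number here means a stronger inhibitor, a higher number a weaker inhibitor), three compounds with a shared core have been measured. Compound 1 `O=C(/C=C/c1ccc2c(c1)B(O)OC2)c1ccc(OCc2ccccc2)cc1` gives > 10 ug/mL, which is a limit and not a number. Compound 2 `O=C(/C=C/c1ccc2c(c1)B(O)OC2)c1ccc(F)cc1` gives > 10 ug/mL, which is also a limit. Compound 3 `Nc1ccc(C(=O)/C=C/c2ccc3c(c2)B(O)OC3)cc1` gives > 10 ug/mL, again a limit. All three therefore stand at the same point: the limit of > 10 ug/mL in this assay, at which 3 of the 3 values shown sit.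

Compound 4 `Cc1ccc(C(=O)/C=C/c2ccc3c(c2)B(O)OC3)cc1` has not yet been measured. It has methyl in place of amino on an aromatic carbon, para to a large group (methyl in place of amino on an aromatic carbon).

Two measured steps change the group on this carbon: a step that the two limits leave unreadable from compound 1 to compound 3, and a step that the two limits leave unreadable from compound 2 to compound 3. Neither shows a size, so they give no sign of any real shift, and no step beyond the scatter is expected in this assay, in either direction. The expected change is a step that the limit leaves unreadable from compound 3 to compound 4. The estimated value for compound 4 is 15 ug/mL, with an expected range from 7 ug/mL to 40 ug/mL. Another limit is the most likely report.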

Compound 4, half-maximal inhibitory concentration: > 10 ug/mL
Compound 4 was reported as a limit (the forecaster's own chance of this, stated with the estimate: 85%); the middle value lies beyond the limit too.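

Compound 4, like compound 1, compound 2 and compound 3, is reported only as a limit, so no step among them can be read in this assay: the limit of > 10 ug/mL in this assay, at which 4 of the 4 values shown sit.

The compounds shown leave open where the true value of each lies, and whether any group at this place would give a measurable value.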